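A few compounds are considered here, and "the series" means these few. Any claim that something is new, unique, unknown or untested is made for them only; others in the source may bear on it.

For the measured compounds named here, the three compounds measured so far share one core, seen in compound 1 `O=S(=O)(NCCCNCc1ccccc1Cl)c1cc(C(F)(F)F)cc(C(F)(F)F)c1`, which in a functional assay on HPAC cells (Homo sapiens) for inhibition, read by MTT assay, with a stated time of 72 h (a higher number here means a weaker inhibitor of growth, a lower number a stronger inhibitor of growth), gives 10000 nM. Compound 2 `CC(C)(C)c1ccc(CNCCCNS(=O)(=O)c2cc(C(F)(F)F)cc(C(F)(F)F)c2)cc1` gives 2300 nM in this assay, and compound 3 `O=S(=O)(NCCCNCc1ccc(Cl)c(Cl)c1)c1cc(C(F)(F)F)cc(C(F)(F)F)c1` gives 2500 nM. Among these numbers compound 3 stands second highest: the step of a 4.0-fold lower number from compound 1 to compound 3 (0.60 log units; beyond the scatter) is modest but beyond the scatter, whereas the step of a 1.1-fold higher number from compound 2 to compound 3 (0.04 log units; within the scatter) lies within it, so nothing separates compound 3 from compound 2. Compound 4 `COc1ccc(CNCCCNS(=O)(=O)c2cc(C(F)(F)F)cc(C(F)(F)F)c2)cc1OC` differs from compound 3 in one place: 3,4-dimethoxyphenyl in place of 3,4-dichlorophenyl on a saturated chain carbon bound to an amine nitrogen. Going by the values given here, no measured step covers this exact change. The steps of a 4.3-fold lower number from compound 1 to compound 2 (0.64 log units; beyond the scatter) and a 4.0-fold lower number from compound 1 to compound 3 (0.60 log units; beyond the scatter) show that replacing the 2-chlorophenyl group lowered the number in both cases tried, and the step of a 1.1-fold higher number from compound 2 to compound 3 (0.04 log units; within the scatter) shows that 4-(tert-butyl)phenyl and 3,4-dichlorophenyl gave numbers that cannot be told apart. Whether the hydrogen-bond acceptors of the 3,4-dimethoxyphenyl group shift the number is not answered by any pair measured here. The writer therefore expects compound 4 to land near compound 3, with a step of a 1.6-fold higher number from compound 3 to compound 4 (0.20 log units; within the scatter) that is expected to stay within or only slightly beyond the scatter. The estimate for compound 4 in this assay is 4000 nM, with a range from 1500 nM to 12000 nM.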

Compound 4, concentration for 50% growth inhibition: 3500 nM
Compound 4: middle estimate off by 1.1-fold (0.06 log units), on the high side; the measured number falls inside the stated range.
By their numbers in this assay, from the lowest: compounds 2, 3 and 4 (each within the scatter of the next); then compound 1.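

In this assay, the 3,4-dimethoxyphenyl group brings hydrogen-bond acceptors that 3,4-dichlorophenyl lacks, yet the step of a 1.4-fold higher number from compound 3 to compound 4 (0.15 log units; within the scatter) shows that adding them at this saturated chain carbon bound to an amine nitrogen does not separate the two compounds. The step of a 1.5-fold higher number from compound 2 to compound 4 (0.18 log units; within the scatter) likewise leaves compound 4 indistinguishable from compound 2, so the three groups now compared at this position, 4-(tert-butyl)phenyl, 3,4-dichlorophenyl and 3,4-dimethoxyphenyl, give numbers that cannot be told apart, whether or not they carry such acceptors. The step of a 2.9-fold lower number from compound 1 to compound 4 (0.46 log units; beyond the scatter) adds a third replacement of 2-chlorophenyl that lowers the number beyond the scatter, and none of the listed replacements goes against this, although the step here is the smallest of the three in printed size.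

Nothing shown explains why these groups give such similar numbers or why compound 1 stands apart from them. Also open, as far as these compounds go, is whether a carboxylic acid or an amine in place of the 3,4-dimethoxyphenyl group, or a longer chain in the shared core, would move the number beyond the scatter from that of compound 4.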